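The source may hold more compounds than are shown below. What is called first, only, known or untested is meant among the compounds shown, and "the series" means these compounds.

Measured compounds:
- compound 1 `C[C@@H](O[C@H]1CN2C(=O)C=C(c3ccccc3)CC2[C@@H]1c1ccc(F)cc1)c1cc(C(F)(F)F)cc(C(F)(F)F)c1`: in an assay on CHO cells for displacement of a labelled ligand from Substance-P receptor (Homo sapiens), in the presence of a further agent that is not named here (a lower number here means a stronger inhibitor, a higher number a weaker inhibitor), compound 1 gives 89.5 nM
- compound 2 `C[C@@H](O[C@H]1CN2C(=O)C=C(c3ccc(C#N)cc3)CC2[C@@H]1c1ccc(F)cc1)c1cc(C(F)(F)F)cc(C(F)(F)F)c1`: in this assay compound 2 gives 53 nM
- compound 3 `C[C@@H](O[C@H]1CN2C(=O)C=C(c3ccc(NS(C)(=O)=O)cc3)CC2[C@@H]1c1ccc(F)cc1)c1cc(C(F)(F)F)cc(C(F)(F)F)c1`: in this assay compound 3 gives 54 nM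

Compound 3 stands second highest of the three numbers, yet all three lie within the scatter of one another: a 1.7-fold lower number from compound 1 to compound 3 (0.22 log units; within the scatter) and a 1.0-fold higher number from compound 2 to compound 3 (0.01 log units; within the scatter), and likewise a 1.7-fold lower number from compound 1 to compound 2 (0.23 log units; within the scatter).

The step to compound 4 `C[C@@H](O[C@H]1CN2C(=O)C=C(c3ccncc3)CC2[C@@H]1c1ccc(F)cc1)c1cc(C(F)(F)F)cc(C(F)(F)F)c1` is pyridin-4-yl in place of 4-(methanesulfonamido)phenyl on a double-bonded ring carbon. Among the compounds with values here, no measured pair covers an exchange of the whole aryl group on that ring carbon; the measured steps only vary what sits on the phenyl, and each of those steps stayed within the scatter. They give no sign that this position is sensitive, but a ring with a hetero atom in place of the phenyl is not covered by them at all.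

On that basis compound 4 is expected to sit close to compound 3, with the step of a 1.3-fold higher number from compound 3 to compound 4 (0.11 log units; within the scatter) estimated as small. The estimate for compound 4 in this assay is 70 nM, with a range from 25 nM to 200 nM.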

Compound 4, half-maximal inhibitory concentration: 8.1 nM
Compound 4: middle estimate off by 8.6-fold (0.94 log units), on the high side; the measured number lies below the stated range.
By their numbers in this assay, from the lowest: compound 4; then compounds 2, 3 and 1 (each within the scatter of the next).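

In this assay, exchanging the whole aryl group on the double-bonded ring carbon moves the number beyond the scatter, which changing the substituent on the phenyl did not do: pyridin-4-yl gives a large step in place of phenyl (an 11-fold lower number from compound 1 to compound 4 (1.04 log units; beyond the scatter)) and modest steps in place of 4-cyanophenyl (a 6.5-fold lower number from compound 2 to compound 4 (0.82 log units; beyond the scatter)) and 4-(methanesulfonamido)phenyl (a 6.7-fold lower number from compound 3 to compound 4 (0.82 log units; beyond the scatter)). The position therefore responds to the identity of the aryl ring, and compound 4 is the most potent of the four, with all its steps beyond the scatter. Nothing measured here explains why pyridin-4-yl stands apart from the three phenyl groups.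

Still open, going by these compounds, is whether the lower number extends to other hetero rings on the same ring carbon, such as a pyrimidine or a thiazole. Also open, on these data alone, is whether a pyridine ring carrying an amine or a methoxy group would keep the number of compound 4.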